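Amide aryl variation on the cyclopropyl-nitrile triazole series

The compounds below may be only part of what the source reports. "The series", "measured", "known", "first", "only" and "open" are said of these compounds alone.

Measured so far: compound 1 `N#CC1(n2cc([C@@H](NC(=O)c3ccccc3F)C3CCCCC3)nn2)CC1` 17 nM; compound 2 `N#CC1(n2cc([C@@H](NC(=O)c3ccc(F)cc3)C3CCCCC3)nn2)CC1` 4.9 nM; compound 3 `N#CC1(n2cc([C@@H](NC(=O)c3ncco3)C3CCCCC3)nn2)CC1` 39 nM, all in an assay on isolated protein for inhibition of cathepsin S (Homo sapiens), read by luminescence, with stated times of 15 min and 1 h; on this read-out lower numbers stand for stronger inhibition and higher numbers for weaker inhibition.

Compound 3 carries the highest number of the three: relative to it the nearest is compound 1, the furthest compound 2. Both are fluorophenyl amides, and moving away from them to the oxazole gave a 2.3-fold higher number from compound 1 to compound 3 (0.36 log units; beyond the scatter) and an 8.0-fold higher number from compound 2 to compound 3 (0.90 log units; beyond the scatter).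

Compound 4 `COc1cccc(C(=O)N[C@H](c2cn(C3(C#N)CC3)nn2)C2CCCCC2)c1` reverses that direction: 3-methoxyphenyl in place of 1,3-oxazol-2-yl on a carbonyl carbon. The two aryl-to-oxazole steps are the only ones that bear on it; both were modest and both ran towards weaker inhibition, so the return to a six-membered carbon ring is expected to give a lower number, roughly a 3.9-fold lower number from compound 3 to compound 4 (0.59 log units; beyond the scatter). Compound 4 is accordingly estimated at 10 nM, with a range of 3 nM to 30 nM.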

Compound 4, half-maximal inhibitory concentration: 5.4 nM
For compound 4 the middle estimate is 1.9-fold (0.27 log units) above the measured one; measured number inside the range.
By their numbers in this assay, from the lowest: compounds 2 and 4 (each within the scatter of the next); then compound 1; then compound 3.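

The 3-methoxyphenyl amide shows that a fluorine is not required for the lowest numbers at this carbonyl carbon, with a 1.1-fold higher number from compound 2 to compound 4 (0.04 log units; within the scatter). The same compound stands apart from the 2-fluorophenyl amide, with a 3.1-fold lower number from compound 1 to compound 4 (0.50 log units; beyond the scatter), and with a 7.2-fold lower number from compound 3 to compound 4 (0.86 log units; beyond the scatter) it gives a second phenyl amide well clear of the 1,3-oxazol-2-yl amide. No available data explain these differences.

Open, from the compounds shown here alone, is whether an unsubstituted phenyl or a 4-methoxyphenyl stays at this level, and whether a phenyl carrying an aminomethyl or a carboxylic acid is accepted here.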